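This account rests on a few compounds, and the source may have more. Where it says the series, first, only, none or still open, it means among the compounds named here.

Compound 1 `COc1ccc2c(c1)NC(=O)CN2c1nc(OCC2CC2)nc2ccccc12` was tested in a functional assay on MDA-MB-231 cells (Homo sapiens) for inhibition, read by sulforhodamine B assay, with a stated time of 48 h (a higher number here means a weaker inhibitor of growth, a lower number a stronger inhibitor of growth), where compound 1 gives 45.2 nM. Among the three compounds measured, compound 1 gives the second highest number. Compound 2 `COc1ccc2c(c1)NC(=O)CN2c1nc(NCc2ccncc2)nc2ccccc12` gives 73.6 nM in this assay, and the step of a 1.6-fold higher number from compound 1 to compound 2 (0.21 log units; within the scatter) does not separate the two. Compound 3 `COc1ccc2c(c1)NC(=O)CN2c1nc(COC(C)=O)nc2ccccc12` gives 8.95 nM, and the step of a 5.1-fold lower number from compound 1 to compound 3 (0.70 log units; beyond the scatter) sets compound 3 apart as the stronger inhibitor of growth of the three.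

Compound 4 `CCOc1nc(N2CC(=O)Nc3cc(OC)ccc32)c2ccccc2n1` has not yet been tested. It differs from compound 1 in one place: methyl in place of cyclopropyl on a saturated chain carbon bound to an oxygen on an aromatic ring. Cut one bond further out, the same difference reads cyclopropylmethoxy to ethoxy.

Going by the values given here, none of the measured steps bears directly on this change. Each measured step swaps the whole group on the aromatic carbon for a different kind of group, whereas the change to compound 4 keeps the oxygen on the aromatic ring and shortens only the chain beyond it. The measured steps range from one within the scatter to one of modest size. For a change confined to the chain, a step of no more than the scatter seems most likely, in either direction.

For compound 4 the expected step is a 1.3-fold higher number from compound 1 to compound 4 (0.12 log units; within the scatter), which would place compound 4 at an estimated 60 nM, within a range from 25 nM to 140 nM.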

Compound 4, concentration for 50% growth inhibition: 15.4 nM
The estimate for compound 4 lay 3.9-fold (0.59 log units) above the measured number, outside the stated range (below it).
By their numbers in this assay, from the lowest: compounds 3 and 4 (each within the scatter of the next); then compounds 1 and 2 (each within the scatter of the next).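

With the oxygen kept in place, ethoxy in place of cyclopropylmethoxy gives a 2.9-fold lower number from compound 1 to compound 4 (0.47 log units; beyond the scatter) in this assay, so a change confined to the chain beyond the oxygen can by itself move the number beyond the scatter. The ethoxy group also stands clear of ((pyridin-4-yl)methyl)amino, with a 4.8-fold lower number from compound 2 to compound 4 (0.68 log units; beyond the scatter), while its step from acetoxymethyl, a 1.7-fold higher number from compound 3 to compound 4 (0.24 log units; within the scatter), does not separate the two groups, showing that a small, plain chain on this aromatic carbon can keep up with the best group seen so far. No supporting measurement is available to explain why removing the cyclopropyl ring goes with a stronger inhibitor of growth.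

Going by these compounds, it remains open how the number would respond to a shorter or longer chain on the same oxygen, such as methoxy, propoxy or butoxy, so two chain lengths cannot yet be read as a trend. On these data alone, whether the oxygen itself matters also remains open, and an ethylamino group in place of ethoxy would put that question directly.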